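The source may hold more compounds than are shown below. What is called first, only, known or untested is meant among the compounds shown, and "the series" means these compounds.

Measured compounds:
Compound 1 `CCCCCCN(CCCCCSc1nc2ccccc2s1)C(=O)Nc1ccc(F)cc1F`, 2730 nM
Compound 2 `CCCCCCN(CCCCCSc1nc2cc([N+](=O)[O-])ccc2[nH]1)C(=O)Nc1ccc(F)cc1F`, 8330 nM

The series rests on the shared core of compound 1, a hexyl-bearing urea linked through a five-carbon chain and a sulfur to a bicyclic aromatic group. Going by the values given here, in an assay on cells (Macrophage) for inhibition of sterol O-acyltransferase 1 (Mus musculus) (a lower number here means a stronger inhibitor, a higher number a weaker inhibitor), compound 1 gives 2730 nM, the lowest of the two numbers so far. Compound 2 carries a 5-nitro-1H-benzimidazol-2-yl on that sulfur instead of the 1,3-benzothiazol-2-yl, and in this assay compound 2 gives 8330 nM; the step of a 3.1-fold higher number from compound 1 to compound 2 (0.48 log units; beyond the scatter) is modest but beyond the scatter.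

Compound 3 `CCCCCCN(CCCCCSc1nc2ccc[nH]c-2n1)C(=O)Nc1ccc(F)cc1F` is the next variation on the same sulfur: a group of 9 heavy atoms (6 carbon, 3 nitrogen; one five-membered aromatic ring with 2 hetero atoms, one six-membered aromatic ring with 1 hetero atom) in place of a group of 9 heavy atoms (7 carbon, 1 nitrogen, 1 sulfur; one five-membered aromatic ring with 2 hetero atoms, one six-membered aromatic ring of carbon only), on a sulfur. As in compound 2, the new group brings one hydrogen-bond donor where compound 1 has none, while keeping two acceptors. Among the compounds with values here, the one step that bears on this change, a 3.1-fold higher number from compound 1 to compound 2 (0.48 log units; beyond the scatter), points toward a weaker inhibitor when the benzothiazole is exchanged for a nitrogen-rich bicycle with a donor. A comparable modest loss is therefore expected for compound 3, a 2.2-fold higher number from compound 1 to compound 3 (0.34 log units; beyond the scatter). Compound 3 is estimated at 6000 nM, with a range from 2500 nM to 15000 nM.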

Compound 3, half-maximal inhibitory concentration: 5470 nM
Compound 3: middle estimate off by 1.1-fold (0.04 log units), on the high side, and the stated range covers the measured number.
By their numbers in this assay, from the lowest: compounds 1, 3 and 2 (each within the scatter of the next, the first and the last beyond it).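

In this assay, exchanging the 1,3-benzothiazol-2-yl on the sulfur for the group of 9 heavy atoms with 3 nitrogens gives a 2.0-fold higher number from compound 1 to compound 3 (0.30 log units; within the scatter), so at this position a ring nitrogen bearing a hydrogen-bond donor and the loss of the ring sulfur do not by themselves produce a step beyond the scatter. The same group also stays within the scatter of the nitro-bearing bicycle, with a 1.5-fold lower number from compound 2 to compound 3 (0.18 log units; within the scatter), which leaves compound 3 unresolved from both neighbours even though a 3.1-fold higher number from compound 1 to compound 2 (0.48 log units; beyond the scatter) separates those two, so the three compounds do not divide into two clear groups at this position. Nothing is available that would explain these numbers, and no independent measurement bears on this change.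

What the compounds shown leave open is whether the nitro group contributes at all, since a plain 1H-benzimidazol-2-yl on the sulfur would separate it from the ring exchange itself. They also leave open how a 1,3-benzoxazol-2-yl, or a methoxy or an amine on the 1,3-benzothiazol-2-yl, would compare with compound 1.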